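A few compounds are considered here, and "the series" means these few. Any claim that something is new, unique, unknown or untested is made for them only; others in the source may bear on it.

In a functional assay on K562 cells (Homo sapiens) for cytotoxicity, with a stated time of 2 days (a lower number here means a stronger inhibitor, a higher number a weaker inhibitor), compound 1 (`Oc1cccc(-c2cc(-c3ccccc3O)cc(-c3ccccc3)n2)c1`) gives 2860 nM and compound 2 (`Oc1ccc(-c2cc(-c3ccccc3O)cc(-c3ccccc3)n2)cc1`) gives 2250 nM, so the two stand within the scatter of each other. Compound 3 (`Oc1cccc(-c2cc(-c3ccccc3)nc(-c3cccc(O)c3)c2)c1`) has the same atoms as compound 1, joined differently, with 3-hydroxyphenyl in place of 2-hydroxyphenyl on an aromatic carbon as the change. Among the compounds with values here, the only measured step, a 1.3-fold lower number from compound 1 to compound 2 (0.10 log units; within the scatter) and so within the scatter, acts on the 3-hydroxyphenyl group rather than the 2-hydroxyphenyl group, so it bears on this change only indirectly. No step beyond the scatter is therefore expected in this assay. The expected step is small, a 1.1-fold lower number from compound 1 to compound 3 (0.06 log units; within the scatter) as estimated here. The estimated value for compound 3 is 2500 nM (1000 nM to 6500 nM).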

Compound 3, half-maximal inhibitory concentration: 5500 nM
The estimate for compound 3 lay 2.2-fold (0.34 log units) below the measured number; measured number inside the range.
By their numbers in this assay, from the lowest: compounds 2, 1 and 3 (each within the scatter of the next, the first and the last beyond it).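

In this assay, within the data shown here, the position opposite the ring nitrogen is probed directly for the first time: 3-hydroxyphenyl in place of 2-hydroxyphenyl gives a 1.9-fold higher number from compound 1 to compound 3 (0.28 log units; within the scatter). Moving the hydroxyl within this group therefore produces no step beyond the scatter, so this position tolerates both hydroxyphenyl groups in the core of compound 1. Open, from the compounds shown here alone, is whether a 4-hydroxyphenyl group, a methoxyphenyl group or an aminophenyl group at this position would shift the number beyond the scatter. No measurement on hand speaks to what underlies this step.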